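The source may report more compounds than this note shows. Statements on the series, on what has been measured and on what is new or still open speak of the compounds shown alone.

Measured so far:
compound 1, `COc1cncc(C2=CC3CC(C2)CN(C)C3)c1` — 15%
compound 2, `C1=C(c2cccnc2)C[C@@H]2CNC[C@H]1C2` — 131%

In an in vitro functional assay on SH-EP1 cells for agonist activity at Neuronal acetylcholine receptor; alpha4/beta2 (Homo sapiens), read by FLIPR and calcium flux (on this read-out lower numbers stand for smaller maximal responses and higher numbers for larger maximal responses), compound 1 gives 15%, the lowest of the two numbers. The nearest value, that of compound 2 with 131%, lies far above it, beyond the scatter. Compound 2 differs from compound 1 in more than one place, so no single step can be read from the pair; the two values only show that compound 2 reaches a much larger maximal response than compound 1.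

Compound 3, `COc1cncc(C2=CC3CNCC(C2)C3)c1`, is not yet measured. Against compound 1 it shows (hydrogen in place of methyl on an amine nitrogen in a ring). Among the measured compounds shown here, no measured step of this kind is available. Compound 3 is expected to reach 70%, with a range from 25% to 125%. The expected step of a number 55 percentage points higher from compound 1 to compound 3 (beyond the scatter) points upward and beyond the scatter. This expectation rests on compound 2, which also carries hydrogen on the amine nitrogen in a ring and gives 131% in this assay; the methoxy group retained in compound 3 leaves the size of the rise uncertain.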

Compound 3, largest response reached (reported as percent of maximum), in percent of the reference or control that the assay uses: 100%
For compound 3 the middle estimate is 30 percentage points below the measured one, within the range that was stated.
By their numbers in this assay, from the lowest: compound 1; then compound 3; then compound 2.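

In this assay, among the compounds shown here, hydrogen in place of methyl on the amine nitrogen in a ring gives a number 85 percentage points higher from compound 1 to compound 3 (beyond the scatter) and is the first change that can be read at a single place. The step is large, and since the methoxy group and the rest of the core of compound 1 stay the same in compound 3, the gap between this pair lies entirely in that one methyl on the nitrogen of the six-membered non-aromatic ring. No measurement at hand explains why the step has this size.

On these data alone, the step rests on a single pair, so whether it holds without the methoxy group, or with a chloro or an amino group in its place, stays open. Also open, as far as these compounds go, is how the maximal response changes when an ethyl group or a longer chain sits on the same amine nitrogen, since methyl and hydrogen are the only two substituents compared there so far.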